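Pyrimidinyl ring substituent variation on the piperidine nitrogen

The source may hold more compounds than are shown below. What is called first, only, known or untested is meant among the compounds shown, and "the series" means these compounds.

Measured compounds in a functional assay on HEK293 cells with Glucose-dependent insulinotropic receptor (Homo sapiens) as the target, read by cAMP accumulation, with a stated time of 60 min; on this read-out lower numbers stand for smaller maximal responses and higher numbers for larger maximal responses:
compound 1 `CCCS(=O)(=O)N1CC=C(c2ccc3c(c2)CC(C2CCN(Cc4ccccc4)CC2)O3)CC1`, 88%
compound 2 `CCCS(=O)(=O)N1CC=C(c2ccc3c(c2)CC(C2CCN(C(=O)OC(C)C)CC2)O3)CC1`, 61%
compound 3 `CCCS(=O)(=O)N1CC=C(c2ccc3c(c2)CC(C2CCN(c4ncc(Cl)cn4)CC2)O3)CC1`, 88%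

Compound 3 stands level with compound 1, the two together the highest of the three numbers; its distance from compound 2 is a number 27 percentage points higher from compound 2 to compound 3 (beyond the scatter). The isopropoxycarbonyl replacement gave a number 27 percentage points lower from compound 1 to compound 2 (beyond the scatter), whereas the 5-chloropyrimidin-2-yl replacement gave no change at the digits printed from compound 1 to compound 3 (within the scatter).

Compound 4 `CCCS(=O)(=O)N1CC=C(c2ccc3c(c2)CC(C2CCN(c4ncc(C5CC5)cn4)CC2)O3)CC1` differs from compound 3 by cyclopropyl in place of chloro on an aromatic carbon. Among the measured compounds shown here, none of the measured steps alters a substituent on the pyrimidinyl ring itself; all concern the group on the amine nitrogen. The nearest information is that two unlike nitrogen substituents, in compound 1 and compound 3, give the same number, so no step beyond the scatter is expected for this smaller change. For compound 4 the estimate is 85%, range 70% to 98%, meaning an expected step of a number 3 percentage points lower from compound 3 to compound 4 (within the scatter).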

Compound 4, largest response reached (Emax), in percent of the reference or control that the assay uses: 85%
Estimate against measurement, compound 4: no gap at the digits printed; the range from low to high includes it.
By their numbers in this assay, from the lowest: compound 2; then compounds 4, 1 and 3 (each within the scatter of the next).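

In this assay, cyclopropyl in place of chloro on the aromatic carbon para to a large group leaves the response within the scatter (a number 3 percentage points lower from compound 3 to compound 4 (within the scatter)), the only step shown that alters this position of the pyrimidinyl ring. The 5-cyclopropylpyrimidin-2-yl group also stays clear of isopropoxycarbonyl on the amine nitrogen (a number 24 percentage points higher from compound 2 to compound 4 (beyond the scatter)) and level with benzyl (a number 3 percentage points lower from compound 1 to compound 4 (within the scatter)). Nothing measured here offers an explanation for these numbers.

Only chloro and cyclopropyl are shown at this position, so the effect of an amine, a methoxy group or a longer chain there remains open. From the compounds shown here alone, whether any group at this position can move the largest response beyond the scatter also remains open.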